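Swapping the aryl group on a shared core

This account rests on a few compounds, and the source may have more. Where it says the series, first, only, none or still open, it means among the compounds named here.

Compound 1 `N#Cc1ccccc1COc1c(-c2ccccc2)oc2cc(O)cc(O)c2c1=O`: > 100000 nM
Compound 2 `O=c1c(OCc2cccc([N+](=O)[O-])c2)c(-c2ccccc2)oc2cc(O)cc(O)c12`: 31000 nM

In an ADME assay on Huh-5-2 cells (Homo sapiens) for cytotoxicity, read by WST assay, with a stated time of 3 days (on this read-out higher numbers stand for lower toxicity in this test and lower numbers for higher toxicity in this test), compound 1 sits at a limit of the measurement rather than a number (the limit of > 100000 nM in this assay, at which 1 of the 2 values shown sits). Compound 3 `COc1cccc(COc2c(-c3ccccc3)oc3cc(O)cc(O)c3c2=O)c1` differs from compound 1 by 3-methoxyphenyl in place of 2-cyanophenyl on a saturated chain carbon bound to an oxygen on an aromatic ring. Among the measured compounds shown here, the only measured step at this place is an at least 3.2-fold lower number from compound 1 to compound 2 (0.50 log units; beyond the scatter), where a 3-nitrophenyl entered instead. On these data alone, a 3-methoxyphenyl is untested here, so for compound 3 a step no larger than that, or none beyond the scatter, is expected: an at least 1.4-fold lower number from compound 1 to compound 3 (0.15 log units; that floor lies within the scatter). Compound 3 is therefore estimated at 70000 nM, within 25000 nM to 200000 nM.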

Compound 3, half-maximal cytotoxic concentration: 28000 nM
Compound 3: middle estimate off by 2.5-fold (0.40 log units), on the high side; the measured number falls inside the stated range.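

In this assay, 3-methoxyphenyl in place of 2-cyanophenyl gives an at least 3.5-fold lower number from compound 1 to compound 3 (0.55 log units; beyond the scatter), so a second group at this place also falls below compound 1. The value of compound 1, > 100000 nM, is a limit and not a number. Methoxy in place of nitro on an aromatic carbon gives a 1.1-fold lower number from compound 2 to compound 3 (0.04 log units; within the scatter), so this read-out does not separate these two groups. The compounds shown leave open whether the drop follows the loss of the 2-cyanophenyl or the arrival of a 3-substituted phenyl. On these data alone, how an amine or a carboxylic acid on that ring would read also remains open.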